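Swapping the Ether Side Chain in a Kinase Inhibitor Series

The source may report more compounds than this note shows. Statements on the series, on what has been measured and on what is new or still open speak of the compounds shown alone.

Of the compounds shown here, two have been measured in an assay for inhibition of serine/threonine-protein kinase Sgk1 (Homo sapiens), with stated times of 30 min and 60 min, in the presence of a further agent that is not named here; a lower number here means a stronger inhibitor, a higher number a weaker inhibitor. Compound 1 `CN1CCC(CNC(=O)c2cc(-c3ccc(NS(=O)(=O)c4cccc(Cl)c4Cl)cc3)nc3[nH]ncc23)C1` gives 14 nM in this assay. Compound 2 `Cc1n[nH]c2nc(-c3ccc(NS(=O)(=O)c4cc(Cl)ccc4F)cc3)nc(OCCC(=O)N(C)C)c12` gives 15 nM in this assay, which is the highest of the two numbers, but its nearest neighbour is compound 1 and the gap between them lies within the scatter, so the two cannot be told apart on these numbers.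

Compound 3 `Cc1n[nH]c2nc(-c3ccc(NS(=O)(=O)c4cc(Cl)ccc4F)cc3)nc(OC3CC(C)(C)NC(C)(C)C3)c12` has not yet been measured. It differs from compound 2 in one place: 2,2,6,6-tetramethylpiperidin-4-yl in place of 2-(dimethylcarbamoyl)ethyl on an oxygen on an aromatic ring. Among the measured compounds shown here, no pair of measured compounds that differ in a single place is available, so there is no measured step to lean on for this change. What can be said is that compound 1, which carries a quite different side chain at the same region of the shared core, gives 14 nM, close to the value of compound 2. On that basis the change is expected to bring no step beyond the scatter, with the step from compound 2 to compound 3 estimated as no change at the digits printed from compound 2 to compound 3 (within the scatter). Compound 3 is therefore expected to give about 15 nM in this assay, most likely between 5 nM and 45 nM.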

Compound 3, half-maximal inhibitory concentration: 3 nM
Estimate against measurement, compound 3: 5.0-fold (0.70 log units) above; the measured number lies below the stated range.
By their numbers in this assay, from the lowest: compound 3; then compounds 1 and 2 (each within the scatter of the next).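

Among the compounds shown here, the group on an oxygen on an aromatic ring proves able to move the number: in this assay, 2,2,6,6-tetramethylpiperidin-4-yl in place of 2-(dimethylcarbamoyl)ethyl gives a 5.0-fold lower number from compound 2 to compound 3 (0.70 log units; beyond the scatter) and thus the first single-place comparison here, with a step beyond the scatter. The exchange alters several things at once, since the entering group has a six-membered non-aromatic ring and a hydrogen-bond donor, whereas the leaving group has neither and carries a double bond outside aromatic rings, so this one step cannot assign the gain to any single feature. Nothing measured here bears on why the number falls.

From the compounds shown here alone, it remains open whether the ring, its nitrogen or its methyl groups account for the step, and a plain piperidin-4-yl group or an open-chain amine such as 2-(dimethylamino)ethyl on the same oxygen would help separate these. Going by these compounds, it is also open whether the same exchange would give a comparable step on a different core, such as that of compound 1, or with a different sulfonamide aryl group.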